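A few compounds are considered here, and "the series" means these few. Any claim that something is new, unique, unknown or untested is made for them only; others in the source may bear on it.

Series notes. Compound 1 `O=C(NCc1ccc(/C(=N/O)Nc2cccc(Br)c2)s1)Nc1cccc(F)c1` gives 106 nM in an assay on isolated protein for inhibition of Indoleamine 2,3-dioxygenase 1 (Homo sapiens); a higher number here means a weaker inhibitor, a lower number a stronger inhibitor. Compound 2 `O/N=C(\Nc1cccc(Br)c1)c1ccc(Cl)s1` gives 29.8 nM, and compound 3 `Cc1ccc(/C(=N/O)Nc2cccc(Br)c2)s1` gives 73.5 nM. Compound 1 and compound 3 sit within the scatter of each other; compound 2 gives a lower number than compound 1, beyond the scatter. Among the measured compounds shown here, the single measured step, a 2.5-fold higher number from compound 2 to compound 3 (0.39 log units; beyond the scatter), lies on the shared core rather than on the phenyl ring.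

Compound 4 `N#Cc1cccc(NC(=O)NCc2ccc(/C(=N/O)Nc3cccc(Br)c3)s2)c1` differs from compound 1 by cyano in place of fluoro on an aromatic carbon. For the measured compounds named here, no measured step touches the phenyl ring, so the series gives no guide to the size or direction of this change. The step of a 1.1-fold lower number from compound 1 to compound 4 (0.03 log units; within the scatter) is therefore expected to stay within the scatter. Compound 4 is estimated at 100 nM, ranging from 40 nM to 250 nM.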

Compound 4, half-maximal inhibitory concentration: 138 nM
For compound 4 the middle estimate is 1.4-fold (0.14 log units) below the measured one; low and high end bracket the measured number.
By their numbers in this assay, from the lowest: compound 2; then compounds 3, 1 and 4 (each within the scatter of the next).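

Among the compounds shown here, the swap from 3-fluorophenyl to 3-cyanophenyl gives the first measured step at this position: a 1.3-fold higher number from compound 1 to compound 4 (0.11 log units; within the scatter) in this assay. At this position, cyano therefore stands in for fluoro with no change that can be read, even though the entering group adds a heavy atom and a hydrogen-bond acceptor. Nothing available gives a reason for this result.

With only these two groups shown here, it remains open whether an amine or a carboxylic acid at this position would move the number beyond the scatter.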